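The source may hold more compounds than are shown below. What is called first, only, known or untested is meant among the compounds shown, and "the series" means these compounds.

Compound 1 `C=C1CC[C@@H]2[C@](C)(CO[Si](c3ccccc3)(c3ccccc3)C(C)(C)C)[C@H](OC(C)=O)CC[C@@]2(C)[C@@H]1C/C=C1/C(=O)OC[C@H]1O` was tested in a functional assay on P388 cells (Mus musculus) for cytotoxicity, read by sulforhodamine B assay (a higher number here means that more compound is needed for the effect, a lower number that less compound is needed), and gave 0.5 uM. Compound 2 `C=C1CC[C@@H]2[C@](C)(CO[Si](c3ccccc3)(c3ccccc3)C(C)(C)C)[C@H](OC(C)=O)CC[C@@]2(C)[C@@H]1C/C=C1/C(=O)OC[C@H]1OC(C)=O` differs from compound 1 by acetyl in place of hydrogen on an oxygen on a saturated carbon, and in this assay compound 2 gave 1.67 uM, so that the step was a 3.3-fold higher number from compound 1 to compound 2 (0.52 log units; beyond the scatter). Compound 3 `C=C1CC[C@@H]2[C@](C)(COC(C)=O)[C@H](O)CC[C@@]2(C)[C@@H]1C/C=C1/C(=O)OC[C@H]1O` carries a different core; how that core differs from the core of compound 1 is not broken down here. In this assay compound 3 gave 2.04 uM, a number beyond the scatter from that of compound 1 and within the scatter of that of compound 2. Compound 4 `C=C1CC[C@@H]2[C@](C)(COC(C)=O)[C@H](O)CC[C@@]2(C)[C@@H]1C/C=C1/C(=O)OC[C@H]1OC(C)=O` is made from compound 3 by the same change, (acetyl in place of hydrogen on an oxygen on a saturated carbon), at the same place. Because the earlier step was a 3.3-fold higher number from compound 1 to compound 2 (0.52 log units; beyond the scatter), a step of similar size is expected here, namely a 2.7-fold higher number from compound 3 to compound 4 (0.43 log units; beyond the scatter). Compound 4 is therefore estimated at 5.5 uM, with a range from 2.5 uM to 14 uM.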

Compound 4, concentration for half-maximal effect: 1.62 uM
Compound 4: middle estimate off by 3.4-fold (0.53 log units), on the high side; the whole stated range lies above it.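

In this assay the same hydroxy to acetoxy change on the core of compound 3 gave a 1.3-fold lower number from compound 3 to compound 4 (0.10 log units; within the scatter). Set beside the earlier step, this shows that the size of the change did not carry over between these two cores: the same change on two cores in this assay, a 3.3-fold higher number (0.52 log units; beyond the scatter) from compound 1 to compound 2 and a 1.3-fold lower number (0.10 log units; within the scatter) from compound 3 to compound 4, 4.2-fold (0.62 log units) apart, beyond the scatter of two such steps. Within the data shown here, with only one pair on each core, it does not show which difference between the cores matters, or how the change would behave on any further core.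

The compounds shown leave open how a longer acyl chain or a carboxylic acid in place of the acetyl would read on either core. They also leave open whether any such group would show the same gap between the two cores.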